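The source may report more compounds than this note shows. Statements on the series, on what has been measured and on what is new or still open speak of the compounds shown alone.

Working notes on the series. In a functional assay on Malme-3M cells (Homo sapiens) for inhibition, read by sulforhodamine B assay, with a stated time of 48 h (a higher number here means a weaker inhibitor of growth, a lower number a stronger inhibitor of growth), compound 1 `Cc1cc(O)cc(-c2nn(CC#N)cc2-c2ccnc(-c3ccc(Oc4ccccc4)cc3)c2)c1` gives 3580 nM. Compound 2 `COc1cc(C)cc(-c2nn(CC#N)cc2-c2ccnc(-c3ccc(N(C)C)cc3)c2)c1` is known in this assay only as a limit, > 100000 nM, which places it at the weak end of the numbers shown (the limit of > 100000 nM in this assay, at which 1 of the 2 values shown sits). Compound 3 `Cc1cc(O)cc(-c2nn(CC#N)cc2-c2ccnc(-c3ccc(N(C)C)cc3)c2)c1` differs from compound 2 by hydrogen in place of methyl on an oxygen on an aromatic ring. Within the data shown here, no measured pair shows this change alone, so a gain beyond the scatter is expected, though its size is unsettled. For compound 3 in this assay the estimate is 20000 nM, within 3000 nM to 100000 nM. The expected step from compound 2 to compound 3 is an at least 5.0-fold lower number from compound 2 to compound 3 (0.69 log units; beyond the scatter).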

Compound 3, concentration for total growth inhibition: 39200 nM
Compound 3: the middle estimate sits 2.0-fold (0.29 log units) below what was measured; the measured number falls inside the stated range.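

In this assay, the change from methoxy to hydroxy now has a step of its own with dimethylamino held constant: an at least 2.5-fold lower number from compound 2 to compound 3 (0.40 log units; beyond the scatter). That size is only a lower bound, as compound 2 is known only as a limit: the limit of > 100000 nM in this assay, at which 1 of the 3 values shown sits. With the hydroxy kept, dimethylamino in place of phenoxy on an aromatic carbon gives an 11-fold higher number from compound 1 to compound 3 (1.04 log units; beyond the scatter).

Going by these compounds, whether the change from methoxy to hydroxy gives a similar step with phenoxy present remains open. So does what an amine or a carboxylic acid in place of the hydroxy would do to the number.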